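Working notes: from compound 2 to compound 3

The compounds below may be only part of what the source reports. "The series", "measured", "known", "first", "only" and "open" are said of these compounds alone.

Measured in a functional assay on PC-3 cells (Homo sapiens) for antiproliferative activity, read by MTT assay, with a stated time of 72 h; a higher number here means a weaker inhibitor, a lower number a stronger inhibitor:
- compound 1 `O=C(N/N=C/c1ccc(Br)cc1)Nc1ccc(Oc2ccnc3[nH]ccc23)c(F)c1`: 920 nM
- compound 2 `O=C(N/N=C/c1ccccc1)Nc1ccc(Oc2ccnc3[nH]ccc23)cc1`: 10200 nM

Of the two measured compounds, compound 2 has the higher number in this assay, at 10200 nM. Compound 1 gives 920 nM, a lower number, and this gap is beyond the scatter.

The next compound is compound 3 `O=C(N/N=C/c1ccc(Br)cc1)Nc1ccc(Oc2ccnc3[nH]ccc23)cc1`. It departs from compound 2 by one change, bromo in place of hydrogen on an aromatic carbon, which turns phenyl into 4-bromophenyl.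

Going by the values given here, the series offers no measured step that differs in one place only, so the size of this change has not been observed directly. Among the compounds with values here, the sole guide is compound 1, which also carries the 4-bromophenyl group and gives 920 nM. It differs from compound 2 in more than one place, so the data do not show how much of the gap goes with the bromo. A move toward a lower number is expected, beyond the scatter but probably not covering the whole gap. The expected change is a 4.1-fold lower number from compound 2 to compound 3 (0.61 log units; beyond the scatter). The estimate for compound 3 is 2500 nM, with an expected range of 800 nM to 8000 nM.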

Compound 3, half-maximal inhibitory concentration: "not active" (no number reported)
The entry for compound 3 holds no number; the estimate stays without a comparison.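

Going by these compounds alone, compound 3 is entered as not active in this assay with no number, so no step from compound 2 can be read. The compounds shown leave open what the change from phenyl to 4-bromophenyl does on its own to the read-out. No further evidence bears on this result.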